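Amine swap on the chain of compound 3

The compounds below may be only part of what the source reports. "The series", "measured", "known", "first", "only" and "open" are said of these compounds alone.

Compound 1 `COc1ccccc1-c1cc(=O)c2c(O)cc(OCCCCN3CCN(C)CC3)c(OC)c2o1` gives 2330 nM in a functional assay on HepG2 cells (Homo sapiens) for cytotoxicity, read by MTT assay, with a stated time of 72 h (a lower number here means a stronger inhibitor, a higher number a weaker inhibitor), and compound 2 `COc1c(OCCCCN2CCN(C)CC2)cc(O)c2c(=O)cc(-c3cccc(F)c3)oc12` gives 2580 nM; the step of a 1.1-fold higher number from compound 1 to compound 2 (0.04 log units; within the scatter) is small. Compound 3 `CCN(CC)CCCOc1c(OCc2ccccc2)cc(O)c2c(=O)cc(-c3ccccc3)oc12` gives 3010 nM, a number within the scatter of both compound 2 and compound 1. Compound 4 `CN1CCN(CCCCOc2c(OCc3ccccc3)cc(O)c3c(=O)cc(-c4ccccc4)oc23)CC1` carries the change ((4-methylpiperazin-1-yl)methyl in place of diethylamino on a saturated chain carbon, three bonds along the chain from an oxygen on an aromatic ring). No measured step covers this exchange of the basic end of the chain; the only step shown, from compound 1 to compound 2, concerns the aryl group and stays within the scatter, and compounds 1 and 2, which already carry the methylpiperazine chain, give numbers close to compound 3. Compound 4 is therefore expected to show no step beyond the scatter, a 1.2-fold lower number from compound 3 to compound 4 (0.06 log units; within the scatter), with an estimate of 2600 nM (range 1200 nM to 5500 nM).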

Compound 4, half-maximal inhibitory concentration: 1500 nM
The estimate for compound 4 lay 1.7-fold (0.24 log units) above the measured number; the range from low to high includes it.
By their numbers in this assay, from the lowest: compounds 4, 1, 2 and 3 (each within the scatter of the next).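

In this assay, for the compounds shown here, the exchange of 3-(diethylamino)propyl for 4-(4-methylpiperazin-1-yl)butyl is the only measured change at the amine end of the chain (a 2.0-fold lower number from compound 3 to compound 4 (0.30 log units; within the scatter)). With the rest of compound 3 unchanged, this exchange therefore gives no step beyond the scatter, so the two chains cannot be told apart here. No evidence at hand bears on this result.

From the compounds shown here alone, the exchange alters the amine and the chain length together, so the contribution of each remains open; a 4-(diethylamino)butyl chain or a 3-(4-methylpiperazin-1-yl)propyl chain would separate them. Going by these compounds, a morpholine at the chain end also remains open.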